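This account rests on a few compounds, and the source may have more. Where it says the series, first, only, none or still open, it means among the compounds named here.

Compound 1, with the structure `CS(=O)(=O)NC(=O)c1ccc(C2CC2c2ccc(OCc3c(-c4c(Cl)cccc4Cl)noc3C3CC3)cc2Cl)cc1`, holds the highest of the three numbers recorded in an assay on HEK293 cells for agonist activity at Bile acid receptor (Homo sapiens); on this read-out lower numbers stand for smaller maximal responses and higher numbers for larger maximal responses: compound 1 gives 88%. The nearest number comes from compound 3, with the structure `Cn1nc(C(=O)O)c2ccc([C@H]3C[C@](O)(c4ccc(OCc5c(-c6c(Cl)cccc6Cl)noc5C5CC5)cc4Cl)C3)cc21`, which gives 82% in this assay, a gap to compound 1 that lies within the usual scatter, so the two cannot be set in order. The furthest is compound 2, with the structure `O=C(O)c1cncc(N2CC(O)(c3ccc(OCc4c(-c5c(Cl)cccc5Cl)noc4C4CC4)cc3Cl)C2)c1`, which gives 71% in this assay, a gap that lies beyond the scatter, so compound 2 stands lower than compound 1.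

Compound 4, with the structure `O=C(NCCS(=O)(=O)O)c1ccc(C2CC2c2ccc(OCc3c(-c4c(Cl)cccc4Cl)noc3C3CC3)cc2Cl)cc1`, has not yet been measured in this assay. It differs from compound 1 in one place: 2-sulfoethyl in place of methylsulfonyl on an amide-type nitrogen. For the measured compounds named here, no pair of measured compounds shows this kind of change, so there is no measured step to lean on; the only guide is the high number of compound 1 and the closeness of compound 3 to it.

From compound 1 to compound 4 the step expected in this assay is a number 4 percentage points lower from compound 1 to compound 4 (within the scatter), that is, no change beyond the scatter is expected in either direction. For compound 4 the maximal response in this assay is accordingly estimated at 84%, with a likely range from 68% to 96%.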

Compound 4, largest response reached (reported as efficacy), in percent of the reference or control that the assay uses: 34%
Compound 4: middle estimate off by 50 percentage points, on the high side, outside the stated range (below it).
By their numbers in this assay, from the lowest: compound 4; then compound 2; then compounds 3 and 1 (each within the scatter of the next).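

Setting 2-sulfoethyl in place of methylsulfonyl on the amide-type nitrogen brings, in this assay, a number 54 percentage points lower from compound 1 to compound 4 (beyond the scatter) and gives the first reading of a single change at this place. The earlier compounds shown here differ from one another in more than one place, so they could not show that the maximal response depends this strongly on what this nitrogen carries; here, (methylsulfonyl)carbamoyl and (2-sulfoethyl)carbamoyl are clearly not interchangeable on the core of compound 1. Nothing among the data shown accounts for this loss.

The compounds shown leave open whether the loss follows the sulfo end, the longer chain that carries it, or the change from a sulfonyl attached directly to the nitrogen to one set further out. A 2-carboxyethyl or 2-hydroxyethyl group on the same nitrogen could begin to separate these readings, and a plain carboxylic acid in place of the whole (methylsulfonyl)carbamoyl group would show how much of the response needs the sulfonyl at all.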